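Adding a methyl to the phenyl ring of compound 3

A few compounds are considered here, and "the series" means these few. Any claim that something is new, unique, unknown or untested is made for them only; others in the source may bear on it.

Measured compounds in a functional assay on MDA-MB-231 cells (Homo sapiens) for antiproliferative activity, read by CCK-8 assay, with a stated time of 72 h; on this read-out lower numbers stand for stronger inhibition and higher numbers for weaker inhibition:
compound 1 `CC1=NN(c2ccc(C)cc2)C(=O)C12C=CC(=O)C=C2c1ccc(C)cc1`, 5110 nM
compound 2 `CC1=NN(c2ccc(Br)cc2)C(=O)C12C=CC(=O)C=C2c1ccccc1`, > 100000 nM
compound 3 `CC1=NN(c2ccc(Cl)cc2)C(=O)C12C=CC(=O)C=C2c1ccccc1`, > 100000 nM

Compound 3 stands at the limit of this assay. Its value > 100000 nM is a limit, not a number, and the same holds for compound 2 at > 100000 nM; two of the three values shown sit at the limit of > 100000 nM in this assay, at which 2 of the 3 values shown sit. Among the measured compounds shown here, because of this the only step between neighbours, a step that the two limits leave unreadable from compound 2 to compound 3, cannot be read in size. For the measured compounds named here, compound 1 is the one compound with a measured number, 5110 nM in this assay.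

Compound 4 `CC1=NN(c2ccc(Cl)cc2)C(=O)C12C=CC(=O)C=C2c1ccc(C)cc1` arises from compound 3 by methyl in place of hydrogen on an aromatic carbon, placed para to a large group; cut one bond further out, the change reads phenyl to 4-methylphenyl. Going by the values given here, no measured step follows this exact change, so no step size can be carried over. What can be said is that compound 1, which carries this methyl together with a methyl on the other aryl ring, gives a number, while compound 3, lacking both, gives only a limit.

On that basis compound 4 is expected to move from the limit toward measurable inhibition, a step of an at least 2.5-fold lower number from compound 3 to compound 4 (0.39 log units; beyond the scatter), with considerable uncertainty. The estimate for compound 4 is 40000 nM, between 6000 nM and 150000 nM.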

Compound 4, half-maximal inhibitory concentration: 14300 nM
For compound 4 the middle estimate is 2.8-fold (0.45 log units) above the measured one, and the stated range covers the measured number.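

In this assay, the change from phenyl to 4-methylphenyl is the first single change shown that brings a compound off the limit, giving an at least 6.9-fold lower number from compound 3 to compound 4 (0.84 log units; beyond the scatter). Going by these compounds, the true size of this step stays unknown, as compound 3 has a limit rather than a number: the limit of > 100000 nM in this assay, at which 2 of the 4 values shown sit. With the 4-methylphenyl group held fixed, the substituent on the other aryl ring also counts, and chloro in place of methyl gives a 2.8-fold higher number from compound 1 to compound 4 (0.45 log units; beyond the scatter), so activity here depends on both aryl rings and not on the new methyl alone.

The compounds shown leave open whether the gain belongs to methyl itself or would also appear with an ethyl, a methoxy or a fluorine on that ring carbon, and whether a longer chain or an amine there would lower the number further. On these data alone, the step between compound 2 and compound 3 cannot be read, as both values are limits, so it also remains open whether bromo and chloro differ once the 4-methylphenyl group is in place.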